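The source may report more compounds than this note shows. Statements on the series, on what has been measured and on what is new or still open speak of the compounds shown alone.

Compound 1 `C=CCc1ccccc1OCC1=NCCN1` gives 61.7 nM in an assay on isolated protein for agonist activity at Alpha-2C adrenergic receptor (Homo sapiens) (a higher number here means that more compound is needed for the effect, a lower number that less compound is needed), the second highest of the three numbers at hand: compound 3 `CCCc1ccccc1OC(C)C1=NCCN1` gives 25.1 nM and compound 2 `c1ccc(OC2CC2)c(OCC2=NCCN2)c1` gives 1000 nM. Among the measured compounds shown here, the only step measured in one place, a 16-fold higher number from compound 1 to compound 2 (1.21 log units; beyond the scatter), concerns a different change and does not bear on the present one. Compound 4 `CCCc1ccccc1OCC1=NCCN1` differs from compound 1 by ethyl in place of vinyl on a saturated chain carbon bound to an aromatic carbon. For the measured compounds named here, compound 3 also carries a propyl group but differs from compound 1 in a second place as well, so its number shows only that a propyl-bearing analogue can sit lower. Going by the values given here, no direct precedent exists for this change, so the step of a 1.5-fold lower number from compound 1 to compound 4 (0.19 log units; within the scatter) is expected to remain modest. Compound 4 is estimated at 40 nM, within 15 nM to 120 nM.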

Compound 4, half-maximal effective concentration: 155 nM
The estimate for compound 4 lay 3.9-fold (0.59 log units) below the measured number; measured number above the stated range.
By their numbers in this assay, from the lowest: compound 3; then compound 1; then compound 4; then compound 2.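

At this place in this assay, the double bond of the allyl group counts: propyl in its place needs more compound (a 2.5-fold higher number from compound 1 to compound 4 (0.40 log units; beyond the scatter)). With propyl held constant, removing the methyl on the saturated chain carbon also raises the number (a 6.2-fold higher number from compound 3 to compound 4 (0.79 log units; beyond the scatter)), yet propyl still needs less compound than cyclopropyloxy on the aromatic carbon (a 6.5-fold lower number from compound 2 to compound 4 (0.81 log units; beyond the scatter)). No measured evidence accounts for the allyl-to-propyl step. Open, as far as these compounds go, is whether a propargyl group or a longer chain such as butyl would sit nearer compound 1 or compound 4.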